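The compounds below may be only part of what the source reports. "The series", "measured", "known", "first", "only" and "open" are said of these compounds alone.

Measured so far, in a functional assay on HCT-116 cells (Homo sapiens) for cytotoxicity, read by sulforhodamine B assay, with a stated time of 48 h; a higher number here means a weaker inhibitor, a lower number a stronger inhibitor:
- compound 1 `COc1cc(/C=C/C(=O)/C=C/c2cccs2)ccc1OCc1cn(CCOc2cc(=O)oc3ccccc23)nn1`: 9290 nM
- compound 2 `COc1ccc(/C=C/C(=O)/C=C/c2ccc(OCc3cn(CCOc4cc(=O)oc5ccccc45)nn3)c(OC)c2)cc1OC`: 4710 nM

Compound 2 gives 4710 nM and compound 1 gives 9290 nM. These two values lie within the scatter of each other, so compound 2 has no demonstrated edge in this assay.

Next in the series is compound 3 `COc1ccc(/C=C/C(=O)/C=C/c2ccc(OCc3cn(CCOc4cc(=O)oc5ccccc45)nn3)c(OC)c2)cc1`. The change is hydrogen in place of methoxy on an aromatic carbon, which turns 3,4-dimethoxyphenyl into 4-methoxyphenyl.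

Going by the values given here, one measured step bears on this, and only indirectly: a 2.0-fold lower number from compound 1 to compound 2 (0.29 log units; within the scatter). That step exchanged thiophen-2-yl for the whole 3,4-dimethoxyphenyl group and stayed within the scatter. Among the compounds with values here, no measured pair isolates a single methoxy group, so the evidence for this change is thin. A smaller edit to the same group is therefore expected to produce no step beyond the scatter, and no direction is favoured.

The expected step is a 1.2-fold higher number from compound 2 to compound 3 (0.07 log units; within the scatter). For compound 3 the estimated value is 5500 nM, with an expected range of 2300 nM to 12000 nM.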

Compound 3, half-maximal inhibitory concentration: 9290 nM
For compound 3 the middle estimate is 1.7-fold (0.23 log units) below the measured one, and the stated range covers the measured number.
By their numbers in this assay, from the lowest: compounds 2, 1 and 3 (each within the scatter of the next).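

In this assay, going by these compounds alone, the first pair that isolates a single methoxy group, ortho to a methoxy group and meta to a large group, gives a 2.0-fold higher number from compound 2 to compound 3 (0.29 log units; within the scatter) and so shows no demonstrated dependence on that methoxy group. The comparison at the same end of the molecule, with 4-methoxyphenyl in place of thiophen-2-yl, gives no change at the digits printed from compound 1 to compound 3 (within the scatter) and adds a second exchange of thiophen-2-yl that stays within the scatter, leaving compound 1, compound 2 and compound 3 unseparated in this assay. No accompanying measurement bears on how these results arise.

Still open, from the compounds shown here alone, is whether a different replacement for this methoxy group, such as a hydroxyl group, an amine or a carboxylic acid, would give a step beyond the scatter. The compounds shown also leave open whether this end of the molecule matters more when the rest of the structure changes, for example with a longer chain in the linker of the shared core.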